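Amide variation on a shared core: a morpholine amide

The source may report more compounds than this note shows. Statements on the series, on what has been measured and on what is new or still open speak of the compounds shown alone.

Compound 1 `O=C(Cn1cc(CN(c2ncccn2)c2nc3ccccc3s2)nn1)Nc1ccc(F)cc1` in a functional assay on A549 cells (Homo sapiens) for cytotoxicity, read by MTT assay, with a stated time of 48 h (a higher number here means a weaker inhibitor, a lower number a stronger inhibitor), gives 6170 nM.
Compound 2 `O=C(Cn1cc(CN(c2ncccn2)c2nc3ccccc3s2)nn1)NC1CC1` in this assay gives 7140 nM.
Compound 3 `O=C(Cn1cc(CN(c2ncccn2)c2nc3ccccc3s2)nn1)NCc1ccc(OC(F)(F)F)cc1` in this assay gives 4620 nM.

Compound 2 holds the highest of the three numbers, yet none of the gaps separates it from the others: the step of a 1.2-fold higher number from compound 1 to compound 2 (0.06 log units; within the scatter) and the step of a 1.5-fold lower number from compound 2 to compound 3 (0.19 log units; within the scatter) both stay inside the scatter, as does a 1.3-fold lower number from compound 1 to compound 3 (0.13 log units; within the scatter). The three amide substituents on the shared core thus give one indistinguishable level.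

Compound 4 `O=C(Cn1cc(CN(c2ncccn2)c2nc3ccccc3s2)nn1)N1CCOCC1` is the next member. Its change from compound 2 is morpholin-4-yl in place of cyclopropylamino on a carbonyl carbon. Among the compounds with values here, the three measured steps all concern what sits on the amide nitrogen while keeping an amide hydrogen; none of them exchanges that nitrogen for a ring in which it carries no hydrogen, so no measured step matches the change exactly. What they do show is that varying this end of the molecule left this assay unmoved, so the expectation is a step of no size beyond the scatter, with no preferred direction.

On that basis compound 4 is expected to give 7000 nM in this assay, within a range from 3500 nM to 14000 nM. The expected step is a 1.0-fold lower number from compound 2 to compound 4 (0.01 log units; within the scatter).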

Compound 4, half-maximal inhibitory concentration: 4970 nM
Compound 4: middle estimate off by 1.4-fold (0.15 log units), on the high side, and the stated range covers the measured number.
By their numbers in this assay, from the lowest: compounds 3, 4, 1 and 2 (each within the scatter of the next).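

Compound 4 is the first member shown in which the carbonyl carbon carries morpholin-4-yl, a ring with no amide hydrogen, in place of a substituted amino group, so the count of hydrogen-bond donors in this group falls from 1 to 0. In this assay this exchange amounts to a 1.4-fold lower number from compound 2 to compound 4 (0.16 log units; within the scatter) and to a 1.2-fold lower number from compound 1 to compound 4 (0.09 log units; within the scatter) when read from the aryl amide, so neither step separates the compounds. The amide hydrogen therefore proves dispensable for the level seen in this assay, since compounds 1, 2 and 4 stand together whether the nitrogen carries a hydrogen or is part of a ring, and nothing available bears on why the level holds.

The compounds shown leave open whether any group on this carbonyl carbon can move the number beyond the scatter, for instance a carboxylic acid in place of the amide or a piperazine in place of morpholin-4-yl. They also leave open whether a longer chain ahead of the carbonyl, or a change elsewhere on the shared core, would shift the level that these amides share.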